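From 2-fluorophenyl to 4-cyanophenyl: an unmeasured swap

The source may hold more compounds than are shown below. What is called first, only, known or untested is meant among the compounds shown, and "the series" means these compounds.

Of the compounds shown here, three sharing a 2-fluorophenyl group have been measured in a functional assay on K562 cells (Homo sapiens) for cytotoxicity, read by MTT assay, with a stated time of 24 h (on this read-out lower numbers stand for stronger inhibition and higher numbers for weaker inhibition), and compound 2 (`COc1cc(/C=C2\CN(C)C/C(=C\c3ccccc3F)C2=O)cc(OC)c1`) gives 6320 nM there. Compound 3 (`CN1C/C(=C\c2ccc(C(F)(F)F)cc2)C(=O)/C(=C/c2ccccc2F)C1`) gives 6340 nM and so stands level with compound 2 within the scatter. Compound 1 (`COc1ccc(/C=C2\CN(C)C/C(=C\c3ccccc3F)C2=O)cc1OC`) gives 18000 nM and this higher number lies beyond the scatter from compound 2.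

Compound 4 (`COc1cc(/C=C2\CN(C)C/C(=C\c3ccc(C#N)cc3)C2=O)cc(OC)c1`) keeps the rest of compound 2 but carries 4-cyanophenyl in place of 2-fluorophenyl on a double-bonded chain carbon bound to a double-bonded ring carbon. For the measured compounds named here, no measured pair isolates this change, so its effect cannot be read directly. Going by the values given here, the only guide is that compound 3 at 6340 nM stays level with compound 2 at 6320 nM even though the two differ in structure. The step expected in this assay is therefore small (a 1.1-fold lower number from compound 2 to compound 4 (0.06 log units; within the scatter)) and no shift beyond the scatter is anticipated in either direction. Compound 4 is estimated at 5500 nM with 2000 nM to 15000 nM as the expected range.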

Compound 4, half-maximal inhibitory concentration: 4650 nM
The estimate for compound 4 lay 1.2-fold (0.07 log units) above the measured number; measured number inside the range.
By their numbers in this assay, from the lowest: compounds 4, 2 and 3 (each within the scatter of the next); then compound 1.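

In this assay, the exchange of 2-fluorophenyl for 4-cyanophenyl on a double-bonded chain carbon bound to a double-bonded ring carbon can now be read directly (a 1.4-fold lower number from compound 2 to compound 4 (0.13 log units; within the scatter)). The earlier compounds shown here offered no pair differing in one place, whereas this pair shows that a larger group carrying a nitrile can stand at this position without a shift beyond the scatter. No measurement shown gives a reason for this outcome.

The compounds shown do not separate the change of substituent from the change of its place on the phenyl ring, so 2-cyanophenyl and 4-fluorophenyl would each be needed to tell the two apart. Also open, going by these compounds, is how this position responds to a group of another kind, such as a carboxylic acid or an amine.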